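Shrinking the side chain of a cathepsin S inhibitor

The source may hold more compounds than are shown below. What is called first, only, known or untested is meant among the compounds shown, and "the series" means these compounds.

Measured so far:
Compound 1, `C[C@@H]1CC[C@H](NC(=O)[C@H](CC2CCCCCC2)NC(=O)c2ccco2)C(=O)CN1S(=O)(=O)c1ccccn1`, gives < 0.4 nM in an assay on isolated protein for inhibition of cathepsin S (Homo sapiens), read by fluorescence (on this read-out higher numbers stand for weaker inhibition and lower numbers for stronger inhibition), which is a limit of the assay rather than a number.
Compound 2, `C[C@@H]1CC[C@H](NC(=O)[C@H](CCC2CCCC2)NC(=O)c2ccco2)C(=O)CN1S(=O)(=O)c1ccccn1`, gives 1.9 nM in this assay.

Among the measured compounds shown here, compound 2 therefore stands as the only compound with an actual number in this assay; the other value shown is a limit. For the measured compounds named here, the single measured step, an at least 4.7-fold higher number from compound 1 to compound 2 (0.67 log units; beyond the scatter), pairs the smaller ring with weaker inhibition, and its true size is open at one end because compound 1 sits at the limit of < 0.4 nM in this assay, at which 1 of the 2 values shown sits.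

Compound 3, `C[C@@H]1CC[C@H](NC(=O)[C@H](CC(C)(C)C)NC(=O)c2ccco2)C(=O)CN1S(=O)(=O)c1ccccn1`, carries tert-butyl in place of cyclopentylmethyl on a saturated chain carbon, two bonds along the chain from an amide-type nitrogen and a carbonyl carbon. This change again removes ring carbons and shortens the side chain, so it runs in the same direction as the measured step, though that step rests on a single pair and nothing here shows whether the loss continues or levels off. Compound 3 is therefore expected to show a 3.2-fold higher number from compound 2 to compound 3 (0.50 log units; beyond the scatter). For compound 3 the estimate in this assay is 6 nM, with a range from 2 nM to 20 nM.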

Compound 3, half-maximal inhibitory concentration: 1.3 nM
Estimate against measurement, compound 3: 4.6-fold (0.66 log units) above, and the stated range ends above it.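

Removing the ring does not carry the earlier loss any further: the step to tert-butyl is a 1.5-fold lower number from compound 2 to compound 3 (0.16 log units; within the scatter), so in this assay this change on the saturated chain carbon gives no readable difference, and a ring is not needed at this position for a low nanomolar value. The cycloheptyl of compound 1 still stands apart from the tert-butyl, with an at least 3.2-fold higher number from compound 1 to compound 3 (0.51 log units; beyond the scatter), so among the three compounds only compound 1 separates from the others. The full size of that gap cannot be fixed because compound 1 carries a limit of the assay and not a number: the limit of < 0.4 nM in this assay, at which 1 of the 3 values shown sits.

The compounds shown leave open whether the edge of compound 1 belongs to the seven-membered ring itself or would also appear with a cyclohexylmethyl group or a longer open chain such as n-hexyl. They also leave open whether the flat stretch from cyclopentylmethyl to tert-butyl continues with a smaller group such as isopropyl. How a side chain carrying an amine or a hydroxyl group would read at this position is open as well.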